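The source may report more compounds than this note shows. Statements on the series, on what has been measured and on what is new or still open speak of the compounds shown alone.

Three compounds share a bridged, two-ring core carrying two phenyl groups, an amine and an oxygen on a saturated carbon; a fourth is still to be measured. Compound 2 `CN(C)C12CC(O)C(C(c3ccccc3)C1)C(c1ccccc1)C2` carries a free hydroxy group and a dimethylamino group, and in an ADME assay on L6 cells (Rattus norvegicus) for cytotoxicity, with a stated time of 72 h (a higher number here means a weaker inhibitor, a lower number a stronger inhibitor), compound 2 gives 133000 nM. Compound 1 `CN(C)C12CC(OC(=O)/C=C/c3ccccc3)C(C(c3ccccc3)C1)C(c1ccccc1)C2` differs from it by a single change, ((2-phenylethenyl)carbonyl in place of hydrogen on an oxygen on a saturated carbon), and in this assay compound 1 gives 3820 nM, so the step is a 35-fold lower number from compound 2 to compound 1 (1.54 log units; beyond the scatter). Compound 3 `OC1CC2(N3CCCCC3)CC(c3ccccc3)C1C(c1ccccc1)C2` keeps the free hydroxy group but differs from compound 2 in the amine, (piperidin-1-yl in place of dimethylamino on a saturated ring carbon); in this assay compound 3 gives 37300 nM, a step of a 3.6-fold lower number from compound 2 to compound 3 (0.55 log units; beyond the scatter). Compound 4 `O=C(/C=C/c1ccccc1)OC1CC2(N3CCCCC3)CC(c3ccccc3)C1C(c1ccccc1)C2` carries the piperidin-1-yl core of compound 3 and on it the same change that turned compound 2 into compound 1, namely ((2-phenylethenyl)carbonyl in place of hydrogen on an oxygen on a saturated carbon). The place of the change is the same in both pairs, so this is the same change made on a core that differs only by piperidin-1-yl in place of dimethylamino on a saturated ring carbon. Because the step of a 35-fold lower number from compound 2 to compound 1 (1.54 log units; beyond the scatter) was large, a step of similar direction is expected here, and a step of about a 25-fold lower number from compound 3 to compound 4 (1.40 log units; beyond the scatter) from compound 3 to compound 4 is estimated, allowing that it may come out smaller on the other core. In this assay compound 4 is expected to give about 1500 nM, most likely between 450 nM and 5000 nM.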

Compound 4, half-maximal inhibitory concentration: 10500 nM
Estimate against measurement, compound 4: 7.0-fold (0.85 log units) below; the measured number lies above the stated range.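

In this assay, placing (2-phenylethenyl)carbonyl on the oxygen still lowers the number on the piperidin-1-yl core (a 3.6-fold lower number from compound 3 to compound 4 (0.55 log units; beyond the scatter)), so the direction of the change carries over, but its size does not: the same change on two cores in this assay, a 35-fold lower number (1.54 log units; beyond the scatter) from compound 2 to compound 1 and a 3.6-fold lower number (0.55 log units; beyond the scatter) from compound 3 to compound 4, 9.8-fold (0.99 log units) apart, beyond the scatter of two such steps. The same result can be read through the amine: with (2-phenylethenyl)carbonyl present, piperidin-1-yl in place of dimethylamino raises the number (a 2.7-fold higher number from compound 1 to compound 4 (0.44 log units; beyond the scatter)), whereas with the free hydroxy group it lowers the number, so the two changes do not simply add up: the same change on two cores in this assay, a 3.6-fold lower number (0.55 log units; beyond the scatter) from compound 2 to compound 3 and a 2.7-fold higher number (0.44 log units; beyond the scatter) from compound 1 to compound 4, 9.8-fold (0.99 log units) apart, beyond the scatter of two such steps. These four compounds show that the gain from this change depends on the amine it is paired with in this series, but they do not show why, and a single pair of cores cannot show how the change would behave on any other core.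

As far as these compounds go, it remains open whether a smaller amine such as pyrrolidin-1-yl, or a ring with a second heteroatom such as morpholin-4-yl, would give a step closer to that of the dimethylamino core or to that of the piperidin-1-yl core. From the compounds shown here alone, it is also open whether the double bond or the phenyl ring of the added group matters, which a 3-phenylpropanoyl or an acetyl group on the same oxygen could help to test.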